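The source may hold more compounds than are shown below. What is called first, only, known or untested is meant among the compounds shown, and "the series" means these compounds.

Of the compounds shown here, three from this series have been measured in a functional assay on COLO 205 cells (Homo sapiens) for inhibition, read by sulforhodamine B assay, with a stated time of 48 h, tested at 50 uM; on this read-out lower numbers stand for less inhibition of growth and higher numbers for more inhibition of growth at the one concentration tested. Compound 1, whose structure is `COc1ccc(/C=C/C(=O)/C=C/c2ccc(OCc3cn(CCCCOc4cc(=O)oc5ccccc45)nn3)c(OC)c2)cc1OC`, gives 53%. Compound 2, with the structure `COc1cccc(/C=C/C(=O)/C=C/c2ccc(OCc3cn(CCCCOc4cc(=O)oc5ccccc45)nn3)c(OC)c2)c1`, gives 46%. Compound 3, with the structure `COc1cccc(/C=C/C(=O)/C=C/c2ccc(OCc3cn(CCCOc4cc(=O)oc5ccccc45)nn3)c(OC)c2)c1`, gives 52%.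

Compound 2 and compound 1 differ in one place: methoxy in place of hydrogen on an aromatic carbon. The step this made, a number 7 percentage points higher from compound 2 to compound 1 (within the scatter), is small and sits within the scatter of the measurement, so the two values cannot be told apart with confidence. How the core of compound 3 differs from the core of compound 2 is not broken down here; what can be said is that compound 3 and compound 2 give values that lie within the scatter of each other, as do compound 3 and compound 1.

Compound 4, whose structure is `COc1ccc(/C=C/C(=O)/C=C/c2ccc(OCc3cn(CCCOc4cc(=O)oc5ccccc45)nn3)c(OC)c2)cc1OC`, has not yet been measured. It differs from compound 3 by the same change that turns compound 2 into compound 1: methoxy in place of hydrogen on an aromatic carbon. The place is the same in both pairs, so the change is the same. Because a number 7 percentage points higher from compound 2 to compound 1 (within the scatter) was within the scatter, the step from compound 3 to compound 4 is also expected to be small, about a number 5 percentage points higher from compound 3 to compound 4 (within the scatter). On that basis compound 4 is estimated to give 57% in this assay. The estimated range for compound 4 runs from 45% to 69%.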

Compound 4, percent growth inhibition at one concentration: 65%
Beside the measured number, compound 4's estimate is 8 percentage points below it; measured number inside the range.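

In this assay, the change from 3-methoxyphenyl to 3,4-dimethoxyphenyl gives a modest step, a number 13 percentage points higher from compound 3 to compound 4 (beyond the scatter). Among these compounds, the same change has now been read on two cores, and the two readings cannot be told apart: the same change on two cores in this assay, a number 7 percentage points higher (within the scatter) from compound 2 to compound 1 and a number 13 percentage points higher (beyond the scatter) from compound 3 to compound 4, 6 percentage points apart, within the scatter of two such steps This fits with the change carrying over from the core of compound 2 to the core of compound 3 without a measurable difference in the size of its step, but it does not prove that the two steps are equal, and only the step on the core of compound 3 stands clear of the scatter; two pairs also say nothing about how the change would behave on any other core.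

The compounds shown leave open what other groups would do at the same aromatic carbon, such as a hydroxyl, an amine, a fluorine or a longer ethoxy chain in place of the added methoxy. They also leave open how the compounds compare across a range of concentrations, as each number here comes from a single tested concentration on one cell line.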